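Bromine to chlorine on the aryl group of compound 2

The compounds below may be only part of what the source reports. "The series", "measured", "known", "first", "only" and "open" are said of these compounds alone.

Of the compounds shown here, two have been measured in a functional assay on PC-12 cells (Rattus norvegicus) for cytotoxicity, read by MTT assay, with stated times of 3 h and 2 h, tested at 0.1 uM; a lower number here means a weaker effect, a higher number a stronger effect of the compound at the concentration tested. Compound 1 `O=C(CCCCC1CCSS1)NCc1cn(CCCCOc2ccc3ccc(=O)oc3c2)nn1` gives 40.5%. Compound 2 `O=C(CCCCC1CCSS1)NCc1cn(CCCCOc2ccc3cc(-c4ccc(Br)cc4)c(=O)oc3c2)nn1` gives 34.2%, and the step of a number 6.3 percentage points lower from compound 1 to compound 2 (within the scatter) separates them, so on the numbers shown compound 2 sits alongside compound 1 rather than apart from it. Compound 3 `O=C(CCCCC1CCSS1)NCc1cn(CCCCOc2ccc3cc(-c4ccc(Cl)cc4)c(=O)oc3c2)nn1` has not yet been measured in this assay. It differs from compound 2 by chloro in place of bromo on an aromatic carbon. Within the data shown here, no measured step in this assay compares one halogen with another on this aromatic carbon; the single step recorded, from compound 1 to compound 2, concerns the whole 4-bromophenyl group and not the swap of bromo for chloro, so it does not bear directly on this change. The step of a number 0.2 percentage points lower from compound 2 to compound 3 (within the scatter) is therefore expected to stay within the scatter. Compound 3 is estimated to give 34%, with a range from 22% to 46%.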

Compound 3, a percentage reported as activity, at one concentration (the size of the read-out at that concentration, not a potency): 38.8%
The estimate for compound 3 lay 4.8 percentage points below the measured number; low and high end bracket the measured number.
By their numbers in this assay, from the lowest: compounds 2, 3 and 1 (each within the scatter of the next).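

In this assay, among these compounds, the swap of bromo for chloro gives the first comparison of two halogens on this aromatic carbon, and a number 4.6 percentage points higher from compound 2 to compound 3 (within the scatter) shows that, at this concentration, the exchange does not separate the two compounds. The second new step, a number 1.7 percentage points lower from compound 1 to compound 3 (within the scatter), shows that the 4-chlorophenyl group, like the 4-bromophenyl group before it, does not stand apart from hydrogen at this place. Nothing available bears on why these numbers fall as they do.

As far as these compounds go, whether an amine or a carboxylic acid in place of the halogen on this aryl group would stand apart from compound 1, compound 2 and compound 3 remains open. The compounds shown also leave open how the read-out behaves at any other concentration.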